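This account rests on a few compounds, and the source may have more. Where it says the series, first, only, none or still open, it means among the compounds named here.

Compound 3 `CCCCCCCCCCCCNC(=O)[C@@H](NC(=O)c1cccs1)[C@@H](C)O` is the starting point. Within the data shown here, in a functional assay on SiHa cells (Homo sapiens) for cytotoxicity, read by MTT assay, with a stated time of 48 h (a higher number here means a weaker inhibitor, a lower number a stronger inhibitor), compound 3 gives 23900 nM, the lowest of the three numbers measured so far. Compound 1 `CCCCCCCCNC(=O)[C@@H](NC(=O)c1cccs1)[C@@H](C)O` gives 91900 nM, and compound 2 `CCCCCCCCNC(=O)[C@@H](NC(=O)/C=C/c1ccccc1)[C@@H](C)O` gives 41400 nM. The change to compound 4 `CCCCCCCCCCCCNC(=O)[C@@H](NC(=O)/C=C/c1ccccc1)[C@@H](C)O` is 2-phenylethenyl in place of thiophen-2-yl on a carbonyl carbon. Two earlier steps bear on this. The same exchange on the shorter chain gave a 2.2-fold lower number from compound 1 to compound 2 (0.35 log units; beyond the scatter), and lengthening the chain gave a 3.8-fold lower number from compound 1 to compound 3 (0.58 log units; beyond the scatter). Since the two changes are now combined, the step expected here is a 2.2-fold lower number from compound 3 to compound 4 (0.34 log units; beyond the scatter), a modest move toward a lower number rather than anything dramatic. The estimate for compound 4 in this assay is therefore 11000 nM, expected to fall between 5000 nM and 24000 nM.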

Compound 4, half-maximal inhibitory concentration: > 200000 nM
Compound 4 was reported as a limit (the forecaster's own chance of this, stated with the estimate: 2%); middle value at least 18-fold (1.25 log units) away from the limit.
By their numbers in this assay, from the lowest: compounds 3 and 2 (each within the scatter of the next); then compound 1. At a limit, above all of these: compound 4.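

In this assay, on the longer chain, 2-phenylethenyl in place of thiophen-2-yl gives an at least 8.3-fold higher number from compound 3 to compound 4 (0.92 log units; beyond the scatter), and adding butyl to the chain carrying 2-phenylethenyl gives an at least 4.8-fold higher number from compound 2 to compound 4 (0.68 log units; beyond the scatter). The group on the carbonyl carbon and the chain therefore do not act independently, and the exchange reverses direction on the longer chain: the same change on two cores in this assay, a 2.2-fold lower number (0.35 log units; beyond the scatter) from compound 1 to compound 2 and an at least 8.3-fold higher number (0.92 log units; beyond the scatter) from compound 3 to compound 4, at least 18-fold (1.26 log units) apart, beyond the scatter of two such steps. The chain step reverses as well once 2-phenylethenyl is present: the same change on two cores in this assay, a 3.8-fold lower number (0.58 log units; beyond the scatter) from compound 1 to compound 3 and an at least 4.8-fold higher number (0.68 log units; beyond the scatter) from compound 2 to compound 4, at least 18-fold (1.26 log units) apart, beyond the scatter of two such steps.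

On these data alone, compound 4 gives > 200000 nM, which is a limit of the assay, so the true size of both steps stays open. Where the reversal sets in along the chain also stays open, and a decyl chain carrying 2-phenylethenyl would bear on that.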